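From Pentyl Ether to Pivaloyl Ester at the Aryl Oxygen

The source may hold more compounds than are shown below. What is called first, only, known or untested is meant among the compounds shown, and "the series" means these compounds.

Three measured compounds share one core and differ only in the alkyl chain on the aryl oxygen. In a functional assay for inhibition of Vanilloid receptor (Rattus norvegicus) (on this read-out higher numbers stand for weaker inhibition and lower numbers for stronger inhibition), compound 1 `CCCCOc1cc(C(C)(C)C)ccc1C/N=C(\S)NCc1ccc(NS(C)(=O)=O)cc1` gives 60 nM, compound 2 `CCCCCOc1cc(C(C)(C)C)ccc1C/N=C(\S)NCc1ccc(NS(C)(=O)=O)cc1` gives 70 nM, and compound 3 `CCCCCCOc1cc(C(C)(C)C)ccc1C/N=C(\S)NCc1ccc(NS(C)(=O)=O)cc1` gives 150 nM. Compound 2 therefore stands second highest of the three numbers, within the scatter of compound 1 and beyond it only against compound 3, which gave a 2.1-fold higher number from compound 2 to compound 3 (0.33 log units; beyond the scatter). Lengthening the chain gave a 1.2-fold higher number from compound 1 to compound 2 (0.07 log units; within the scatter) and a 2.5-fold higher number from compound 1 to compound 3 (0.40 log units; beyond the scatter), so growing the chain cost a little but not much.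

Compound 4 `CC(C)(C)C(=O)Oc1cc(C(C)(C)C)ccc1C/N=C(\S)NCc1ccc(NS(C)(=O)=O)cc1` differs from compound 2 by (tert-butyl)carbonyl in place of pentyl on an oxygen on an aromatic ring. For the measured compounds named here, no measured step touches a carbonyl or an ester at this oxygen; the three chain steps only show that this position tolerates change with modest consequence. With nothing to anchor the direction, the estimate for compound 4 is expected to sit near compound 2 with a wide range, as a 2.1-fold higher number from compound 2 to compound 4 (0.33 log units; beyond the scatter) in this assay. Compound 4 is accordingly estimated at 150 nM, between 40 nM and 600 nM.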

Compound 4, half-maximal inhibitory concentration: 220 nM
Beside the measured number, compound 4's estimate is 1.5-fold (0.17 log units) below it, and the stated range covers the measured number.
By their numbers in this assay, from the lowest: compounds 1 and 2 (each within the scatter of the next); then compounds 3 and 4 (each within the scatter of the next).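

In this assay, replacing an alkyl chain on the aryl oxygen with (tert-butyl)carbonyl gives a 3.1-fold higher number from compound 2 to compound 4 (0.50 log units; beyond the scatter) and, against the shorter chain, a 3.7-fold higher number from compound 1 to compound 4 (0.56 log units; beyond the scatter), so this oxygen accepts an ester carrying a carbonyl and a hydrogen-bond acceptor at only a modest cost. Against the longest chain the change gives a 1.5-fold higher number from compound 3 to compound 4 (0.17 log units; within the scatter), which places compound 3 and compound 4 together as one group, with compound 1 and compound 2 forming a separate group of lower numbers. The compounds shown come with no measurement that could explain the size of these steps, so they stand here as description alone.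

As far as these compounds go, what remains open is whether the shift belongs to the carbonyl or to the tert-butyl end of the new group, as compound 4 differs from each of the alkyl ethers in both at once. An acetyl or straight-chain pentanoyl ester, or a neopentyl ether, on the same oxygen would separate those two parts, and a carbamate would show whether the ester link itself matters.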